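The source may report more compounds than this note shows. Statements on the series, on what has been measured and on what is new or still open speak of the compounds shown alone.

The measured compounds are:
compound 1 `c1cc(-c2cn[nH]c2)c2c(c1)C(c1ncc[nH]1)CC2` – 14 nM
compound 2 `Cc1c(OCC2=NCCN2)ccc(Cl)c1NS(C)(=O)=O` – 25 nM
compound 3 `CCS(=O)(=O)Nc1cccc(Cc2c[nH]cn2)c1` – 9 nM

In a functional assay on CHO cells for agonist activity at Alpha-1A adrenergic receptor (Homo sapiens), read by FLIPR and calcium flux (on this read-out higher numbers stand for an effect only at larger amounts of compound and lower numbers for an effect already at smaller amounts), compound 1 gives the second highest of the three numbers. Its nearest neighbour is compound 3, its most distant compound 2, and both gaps lie within the usual scatter, so the three compounds cannot be ranked against one another on these data.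

The unmeasured compound 4 `c1cncc(-c2cccc3c2CCC3c2ncc[nH]2)c1` differs from compound 1 in a single place: pyridin-3-yl in place of 1H-pyrazol-4-yl on an aromatic carbon. For the measured compounds named here, no pair of measured compounds shows a step of this kind, so no measured precedent guides the expectation. The change is expected to shift the number of compound 4 toward a slightly higher value, a step of a 2.1-fold higher number from compound 1 to compound 4 (0.33 log units; beyond the scatter) that may not exceed the scatter. Compound 4 is therefore estimated at 30 nM, with a range from 8 nM to 120 nM.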

Compound 4, half-maximal effective concentration: 2060 nM
Estimate against measurement, compound 4: 69-fold (1.84 log units) below; the whole stated range lies below it.
By their numbers in this assay, from the lowest: compounds 3, 1 and 2 (each within the scatter of the next, the first and the last beyond it); then compound 4.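

For the compounds shown here, at this aromatic carbon the group is far from interchangeable: in this assay, pyridin-3-yl in place of 1H-pyrazol-4-yl gives a 150-fold higher number from compound 1 to compound 4 (2.17 log units; beyond the scatter), a large step that the earlier compounds, with no steps among them, could not show. The exchange replaces a five-membered ring carrying a hydrogen-bond donor with a six-membered ring carrying none. Nothing available here explains the size of this step.

The compounds shown leave open whether ring size or the lost donor matters. A phenyl ring or a 1H-imidazol-4-yl group at this place could begin to separate the two.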